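A few compounds are considered here, and "the series" means these few. Any claim that something is new, unique, unknown or untested is made for them only; others in the source may bear on it.

Of the compounds shown here, three that share one core have been tested in a functional assay on A549 cells (Homo sapiens) for antiproliferative activity, read by CCK-8 assay, with a stated time of 72 h; on this read-out higher numbers stand for weaker inhibition and lower numbers for stronger inhibition. Compound 1 (`CCOc1cc(C(C)(C)C)ccc1C1=NC(c2ccc(Cl)cc2)C(c2ccc(Cl)cc2)N1C(=O)N1CCN(CCCCCC(=O)NO)CC1`) gives 2910 nM, compound 2 (`CCOc1cc(C(C)(C)C)ccc1C1=NC(c2ccc(Cl)cc2)C(c2ccc(Cl)cc2)N1C(=O)N1CCN(CCCCC(=O)NO)CC1`) gives 3780 nM, and compound 3 (`CCOc1cc(C(C)(C)C)ccc1C1=NC(c2ccc(Cl)cc2)C(c2ccc(Cl)cc2)N1C(=O)N1CCN(c2ncc(C(=O)NO)cn2)CC1`) gives 1970 nM. Compound 3 lies within the scatter of both the others, so these numbers do not separate it from them.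

Compound 4 (`CCOc1cc(C(C)(C)C)ccc1C1=NC(c2ccc(Cl)cc2)C(c2ccc(Cl)cc2)N1C(=O)N1CCN(CCCCCCCC(=O)NO)CC1`) carries 7-(hydroxycarbamoyl)heptyl in place of the 5-(hydroxycarbamoyl)pyrimidin-2-yl of compound 3, on an amine nitrogen in a ring (7-(hydroxycarbamoyl)heptyl in place of 5-(hydroxycarbamoyl)pyrimidin-2-yl on an amine nitrogen in a ring). Among the compounds with values here, three measured steps bear on this change. Replacing a chain with the same pyrimidine group gave a 1.5-fold lower number from compound 1 to compound 3 (0.17 log units; within the scatter) and a 1.9-fold lower number from compound 2 to compound 3 (0.28 log units; within the scatter), and changing the chain length gave a 1.3-fold higher number from compound 1 to compound 2 (0.11 log units; within the scatter). All three stay within the scatter, though no chain as long as the heptyl has been measured. No step beyond the scatter is therefore expected in this assay. The expected step is a 1.3-fold higher number from compound 3 to compound 4 (0.10 log units; within the scatter). Compound 4 is estimated at 2500 nM, with an expected range from 1000 nM to 6000 nM.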

Compound 4, half-maximal inhibitory concentration: 2010 nM
Estimate against measurement, compound 4: 1.2-fold (0.09 log units) above; low and high end bracket the measured number.
By their numbers in this assay, from the lowest: compounds 3, 4, 1 and 2 (each within the scatter of the next).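

In this assay, the open 7-(hydroxycarbamoyl)heptyl chain in place of the ring-bearing 5-(hydroxycarbamoyl)pyrimidin-2-yl gives a 1.0-fold higher number from compound 3 to compound 4 (0.01 log units; within the scatter) and so is not told apart from it at this amine nitrogen. The heptyl chain, longer than any measured before, also stays close to the shorter chains, with a 1.9-fold lower number from compound 2 to compound 4 (0.27 log units; within the scatter) and a 1.4-fold lower number from compound 1 to compound 4 (0.16 log units; within the scatter) as the steps, so across these three chain lengths the numbers show no effect of length. No measurement shown here offers a reason for this flat picture.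

On these data alone, whether a much longer chain or a chain of only two carbons would move the number beyond the scatter remains open. All four compounds end in hydroxycarbamoyl, so what a carboxylic acid or a primary amide at that end would do cannot be read.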